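The compounds below may be only part of what the source reports. "The series", "measured", "known", "first", "only" and "open" are said of these compounds alone.

Measured so far:
- compound 1 `CC1SC(c2cccc(C(=O)NCCCCc3ccccc3)c2)N(c2ccc(C3CC3)cc2)C1=O`: 191 nM
- compound 2 `O=C(NCCCCc1ccccc1)c1cccc(C2SCC(=O)N2c2ccc(-c3ccccc3)cc2)c1`: > 1000 nM

In a functional assay on HOS-TE85 cells (Homo sapiens) for inhibition, read by CCK-8 assay, with a stated time of 72 h (a lower number here means a stronger inhibitor, a higher number a weaker inhibitor), compound 1 gives 191 nM. For compound 2 the value of > 1000 nM in this assay is only a limit of the assay, not a number; compound 2 therefore sits at the limit of > 1000 nM in this assay, at which 1 of the 2 values shown sits, and its distance to compound 1 cannot be stated as a step.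

Compound 3 `O=C(NCCCCc1ccccc1)c1cccc(C2SCC(=O)N2c2nccs2)c1` has not been measured. It differs from compound 2 in one place: 1,3-thiazol-2-yl in place of 4-phenylphenyl on an amide-type nitrogen in a ring. Since compound 2 is known only as a limit, the step to compound 3 is not fixed from the shown values. For the measured compounds named here, the one measured compound with a number, compound 1, carries a smaller group on the same amide-type nitrogen than compound 2, so a step toward stronger inhibition is expected, of the size given by an at least 1.1-fold lower number from compound 2 to compound 3 (0.04 log units; that floor lies within the scatter), though the number may again fall outside the range of this assay. The estimate for compound 3 in this assay is 900 nM, between 200 nM and 4000 nM.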

Compound 3, half-maximal inhibitory concentration: > 1000 nM
Compound 3: a limit, no number (the forecaster's own chance of this, stated with the estimate: 40%); middle value at least 1.1-fold (0.04 log units) away from the limit.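

In this assay, for the compounds shown here, compound 3 gives > 1000 nM as a limit and not a number, and compound 2 also stands only as a limit, so no step between compound 2 and compound 3 can be read. The compounds shown leave open how 1,3-thiazol-2-yl and 4-phenylphenyl on the amide-type nitrogen rank.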